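The source may hold more compounds than are shown below. What is called first, only, known or untested is meant among the compounds shown, and "the series" means these compounds.

Measured compounds:
compound 1, `CCC1=C(O)c2c(oc(-c3ccc(C)cc3C)cc2=O)C(CC)(CC)C1=O`, 41.2 uM in a functional assay on KB cells (Homo sapiens) for antiproliferative activity, read by sulforhodamine B assay, with a stated time of 3 days; a lower number here means that less compound is needed, a higher number that more compound is needed for the effect;
compound 2, `CCC1=C(O)c2c(oc(-c3cc(C)c(C)cc3C)cc2=O)C(CC)(CC)C1=O`, 8.2 uM in this assay.

Compound 2 stands lowest of the two numbers in this assay, and the only step shown, a 5.0-fold lower number from compound 1 to compound 2 (0.70 log units; beyond the scatter), is what took it there. Compound 3, `CCC1=C(O)c2c(oc(-c3cc(C)ccc3C)cc2=O)C(CC)(CC)C1=O`, differs from compound 2 by hydrogen in place of methyl on an aromatic carbon. This is the same kind of change as that step but in the opposite direction and at another aromatic carbon, so a higher number in this assay is expected for compound 3, of uncertain size. Compound 3 is therefore estimated at 25 uM (range 8 uM to 80 uM), which is expected to mean a 3.0-fold higher number from compound 2 to compound 3 (0.48 log units; beyond the scatter).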

Compound 3, concentration for half-maximal effect: 14.5 uM
Compound 3: middle estimate off by 1.7-fold (0.24 log units), on the high side; the range from low to high includes it.
By their numbers in this assay, from the lowest: compounds 2 and 3 (each within the scatter of the next); then compound 1.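

In this assay the loss of the methyl para to a large group gives a 1.8-fold higher number from compound 2 to compound 3 (0.25 log units; within the scatter) and so does not separate 2,4,5-trimethylphenyl from 2,5-dimethylphenyl. The change from 2,4-dimethylphenyl to 2,5-dimethylphenyl gives a 2.8-fold lower number from compound 1 to compound 3 (0.45 log units; beyond the scatter) and shows that, in these compounds, where the second methyl stands on the ring does register in this assay. Nothing at hand speaks to the cause of this. 

Still open, on these data alone, is whether a methoxy group, a chlorine atom or an amine on these ring carbons would give numbers like those seen with methyl.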